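Cytotoxicity on Vero cells: aryl swaps on the pyridine position

A few compounds are considered here, and "the series" means these few. Any claim that something is new, unique, unknown or untested is made for them only; others in the source may bear on it.

Compound 3 `COc1nc(-c2ccsc2)ccc1[C@@H](c1ccccc1)[C@@](O)(CCN(C)C)c1cccc2ccccc12` gives 24.4 ug/mL in a toxicity assay on Vero cells (Chlorocebus sabaeus) for cytotoxicity; on this read-out higher numbers stand for lower toxicity in this test and lower numbers for higher toxicity in this test. Of the two numbers recorded so far this is the lowest; its nearest neighbour is compound 1 `COc1nc(C(C)(C)C)ccc1[C@@H](c1ccccc1)[C@@](O)(CCN(C)C)c1cccc2ccccc12`, which gives 27.6 ug/mL, a gap within the scatter (a 1.1-fold lower number from compound 1 to compound 3 (0.05 log units; within the scatter)). Compound 2 `COc1nc(-c2ccccc2F)ccc1[C@@H](c1ccccc1)[C@@](O)(CCN(C)C)c1cccc2ccccc12` returns only a limit in this assay, > 50 ug/mL (the limit of > 50 ug/mL in this assay, at which 1 of the 3 values shown sits). The step of an at least 2.0-fold lower number from compound 2 to compound 3 (0.31 log units; beyond the scatter) is the one beyond the scatter.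

Compound 4 `COc1nc(-c2ccncc2)ccc1[C@@H](c1ccccc1)[C@@](O)(CCN(C)C)c1cccc2ccccc12` differs from compound 3 by pyridin-4-yl in place of thiophen-3-yl on an aromatic carbon. Within the data shown here, no measured step carries exactly this change. Among the measured compounds shown here, the steps that bear on it are a 1.1-fold lower number from compound 1 to compound 3 (0.05 log units; within the scatter), which was flat, and an at least 2.0-fold lower number from compound 2 to compound 3 (0.31 log units; beyond the scatter), where a six-membered aryl gave the higher number and the five-membered thiophene the lower one. A six-membered aryl entering again is therefore expected to move the number somewhat up, by about a 1.4-fold higher number from compound 3 to compound 4 (0.16 log units; within the scatter), with a fair chance that only a limit is reported. Compound 4 is expected at 35 ug/mL, within 18 ug/mL to 70 ug/mL.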

Compound 4, half-maximal cytotoxic concentration: > 50 ug/mL
Compound 4: only a limit was reported; the forecaster's own chance of this, stated with the estimate: 30%; at least 1.4-fold (0.15 log units) between middle value and limit.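

In this assay, a second six-membered aryl separates from thiophen-3-yl at this position, with an at least 2.0-fold higher number from compound 3 to compound 4 (0.31 log units; beyond the scatter), so the earlier gap is not confined to 2-fluorophenyl and also appears with a ring nitrogen in the incoming group. Against tert-butyl the same group gives an at least 1.8-fold higher number from compound 1 to compound 4 (0.25 log units; that floor lies within the scatter), and with that floor inside the scatter, compound 4 cannot yet be placed apart from compound 1. Compound 2 and compound 4 both stop at a limit, so the step between them cannot be read: the limit of > 50 ug/mL in this assay, at which 2 of the 4 values shown sit.

On these data alone, the true values of compound 2 and compound 4 remain open, and with them any order between the two aryl groups. Also open is whether the higher numbers extend to an amine or a carboxylic acid at this position, since thiophen-3-yl is the only five-membered aromatic ring shown.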